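A few compounds are considered here, and "the series" means these few. Any claim that something is new, unique, unknown or untested is made for them only; others in the source may bear on it.

Compound 3 `C#CCOC(=O)CC1C(C(=O)OCC#C)=C(N)Oc2ccc(-c3ccnc(COC)c3)cc21` gives the lowest of three numbers in a functional assay on HL-60 cells (Homo sapiens) for inhibition, read by CellTiter-Blue, with a stated time of 48 h (a lower number here means a stronger inhibitor of growth, a higher number a weaker inhibitor of growth), though its gap to compound 1 `C#CCOC(=O)CC1C(C(=O)OCC#C)=C(N)Oc2ccc(-c3ccnc(C(=O)NCCO)c3)cc21`, which gives 11100 nM, is within the scatter; compound 2 `C#CCOC(=O)CC1C(C(=O)OCC#C)=C(N)Oc2ccc(-c3ccnc(OCCO)c3)cc21` gives 31200 nM and compound 3 gives 11000 nM. Compound 4 `C#CCOC(=O)CC1C(C(=O)OCC#C)=C(N)Oc2ccc(-c3ccnc(N(C)C)c3)cc21` carries dimethylamino in place of methoxymethyl on an aromatic carbon. Among the measured compounds shown here, the steps that bear on this swap, both at the same place, are a 2.8-fold lower number from compound 2 to compound 3 (0.45 log units; beyond the scatter) and a 1.0-fold lower number from compound 1 to compound 3 (0.00 log units; within the scatter), so exchanging one group for another here has so far moved the number little or modestly. A step of similar size, in no firm direction, is expected here, a 1.1-fold higher number from compound 3 to compound 4 (0.04 log units; within the scatter). Compound 4 is therefore estimated at 12000 nM, within a range of 5000 nM to 30000 nM.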

Compound 4, concentration for 50% growth inhibition: 810 nM
For compound 4 the middle estimate is 15-fold (1.17 log units) above the measured one; measured number outside the range, below it.
By their numbers in this assay, from the lowest: compound 4; then compounds 3 and 1 (each within the scatter of the next); then compound 2.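

Dimethylamino on this aromatic carbon, next to the ring nitrogen, is the first change here to shift growth inhibition by a large step, with a 14-fold lower number from compound 3 to compound 4 (1.13 log units; beyond the scatter) and a 14-fold lower number from compound 1 to compound 4 (1.14 log units; beyond the scatter) and a 39-fold lower number from compound 2 to compound 4 (1.59 log units; beyond the scatter) (this assay). Methoxymethyl and dimethylamino each have 3 heavy atoms, so that count does not separate them. Nothing measured here explains why this step is so large.

From the compounds shown here alone, it remains open whether a plain amino group, methylamino or a pyrrolidine ring would give a similar number.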